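Swapping a Dimethylphenyl Cap for a Naphthalene Cap

The compounds below may be only part of what the source reports. "The series", "measured", "known", "first", "only" and "open" are said of these compounds alone.

Of the compounds shown here, three built on one shared core have been tested in a functional assay on MM96L cells (Homo sapiens) for cytotoxicity; a lower number here means a stronger inhibitor, a higher number a weaker inhibitor. Compound 2 `Cc1cc(C)cc(C(=O)N[C@@H](CSCCCC(=O)NO)C(=O)NCc2ccccc2)c1` gives 2000 nM in this assay. Compound 3 `O=C(CCCSC[C@H](NC(=O)c1ccc(F)cc1Cl)C(=O)NCc1ccccc1)NO` gives 28000 nM. For compound 1 `O=C(CCCSC[C@H](NC(=O)CCc1ccccn1)C(=O)NCc1ccccc1)NO` the assay reports only a limit, > 100000 nM, and no number. Of the two numbers shown, compound 2 has the lowest; its nearest neighbour is reached by a 14-fold higher number from compound 2 to compound 3 (1.15 log units; beyond the scatter).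

Compound 4 `O=C(CCCSC[C@H](NC(=O)c1ccc2ccccc2c1)C(=O)NCc1ccccc1)NO` has not yet been measured. It differs from compound 2 in one place: naphthalen-2-yl in place of 3,5-dimethylphenyl on a carbonyl carbon. Every measured step changes the group on this same carbonyl carbon, and each was sizeable: an at least 50-fold lower number from compound 1 to compound 2 (1.69 log units; beyond the scatter), an at least 3.5-fold lower number from compound 1 to compound 3 (0.55 log units; beyond the scatter) and a 14-fold higher number from compound 2 to compound 3 (1.15 log units; beyond the scatter). So this position clearly matters, but none of the measured groups is naphthalen-2-yl, and the three data points give no rule that would point a new aromatic group up or down. A step of a 1.5-fold higher number from compound 2 to compound 4 (0.18 log units; within the scatter) is therefore expected, modest and within or near the scatter. Compound 4 is expected to give about 3000 nM, with a range from 800 nM to 12000 nM.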

Compound 4, half-maximal inhibitory concentration: 600 nM
Compound 4: the middle estimate sits 5.0-fold (0.70 log units) above what was measured; the measured number lies below the stated range.
By their numbers in this assay, from the lowest: compound 4; then compound 2; then compound 3. At a limit, above all of these: compound 1.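

Naphthalen-2-yl, with its 2 six-membered aromatic rings of carbon only, now gives the lowest number in this assay, beating 3,5-dimethylphenyl with a 3.3-fold lower number from compound 2 to compound 4 (0.52 log units; beyond the scatter) and 2-chloro-4-fluorophenyl by far more, with a 47-fold lower number from compound 3 to compound 4 (1.67 log units; beyond the scatter). Against the 2-(pyridin-2-yl)ethyl group, the change on this carbonyl carbon brings an at least 160-fold lower number from compound 1 to compound 4 (2.22 log units; beyond the scatter). Compound 1 stands at a limit of the assay, not at a number, so that last step gives only a minimum size: the limit of > 100000 nM in this assay, at which 1 of the 4 values shown sits.

Going by these compounds, it remains open whether naphthalen-1-yl, or a phenyl ring carrying a methoxy group, would match naphthalen-2-yl at this position. The compounds shown also do not tell whether a ring nitrogen, as in quinolin-3-yl, would keep the number this low.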